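The compounds below may be only part of what the source reports. "The series", "measured", "known", "first", "only" and "open" are said of these compounds alone.

Measured in a functional assay for inhibition of sodium/hydrogen exchanger (Oryctolagus cuniculus); a higher number here means a weaker inhibitor, a lower number a stronger inhibitor:
compound 1 `Cc1cc(-c2ccccc2)c(S(C)(=O)=O)cc1C(=O)N=C(N)N` gives 19 nM; compound 2 `Cc1cc(Sc2cccc(Cl)c2)c(S(C)(=O)=O)cc1C(=O)N=C(N)N` gives 37 nM; compound 3 `Cc1cc(N)c(S(C)(=O)=O)cc1C(=O)N=C(N)N` gives 16 nM.

Compound 3 stands at the low end of the three numbers: compound 1 sits within the scatter of it, and compound 2 is separated from it by a 2.3-fold lower number from compound 2 to compound 3 (0.36 log units; beyond the scatter). Compound 4 `Cc1cc(Oc2cncc(Cl)c2)c(S(C)(=O)=O)cc1C(=O)N=C(N)N` differs from compound 3 by (5-chloropyridin-3-yl)oxy in place of amino on an aromatic carbon. For the measured compounds named here, two measured steps bear on this. a 1.2-fold lower number from compound 1 to compound 3 (0.07 log units; within the scatter) shows no change beyond the scatter when amino replaces phenyl, whereas a 2.3-fold lower number from compound 2 to compound 3 (0.36 log units; beyond the scatter) shows a modest drop in the number when amino replaces (3-chlorophenyl)sulfanyl. The (5-chloropyridin-3-yl)oxy group entering in compound 4 is closer in kind to the latter than to plain phenyl, so a modest rise in this assay is expected, toward the number of compound 2. The expected step is a 1.9-fold higher number from compound 3 to compound 4 (0.27 log units; within the scatter). Compound 4 is estimated at 30 nM, with a range of 12 nM to 75 nM.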

Compound 4, half-maximal inhibitory concentration: 14 nM
Beside the measured number, compound 4's estimate is 2.1-fold (0.33 log units) above it, and the stated range covers the measured number.
By their numbers in this assay, from the lowest: compounds 4, 3, 1 and 2 (each within the scatter of the next, the first and the last beyond it).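

For this assay the position ortho to a methylsulfonyl group accepts (5-chloropyridin-3-yl)oxy with a 1.1-fold lower number from compound 3 to compound 4 (0.06 log units; within the scatter) and with a 1.4-fold lower number from compound 1 to compound 4 (0.13 log units; within the scatter) so neither amino nor phenyl is set apart from it here. Only the exchange against (3-chlorophenyl)sulfanyl goes beyond the scatter, with a 2.6-fold lower number from compound 2 to compound 4 (0.42 log units; beyond the scatter) and that exchange alters both the linking atom and the ring, so the step cannot be tied to either. No evidence at hand accounts for these steps. Still open, on these data alone, are the separate contributions of the linking oxygen and the ring nitrogen, and how a carboxylic acid or a longer alkyl chain at this position would read.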